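The compounds below may be only part of what the source reports. "The series", "measured", "known", "first", "only" and "open" are said of these compounds alone.

Measured so far in an ADME assay on MT4 cells (Homo sapiens) for cytotoxicity, read by MTT assay, with a stated time of 96 h; on this read-out lower numbers stand for higher toxicity in this test and higher numbers for lower toxicity in this test:
Compound 1 `CCCCCCCCOc1ccc2c(=O)c(Cc3c(OC(C)=O)ccc4c(C)cc(=O)oc34)c(N(CC)CC)oc2c1` sits at the limit of the assay, > 100000 nM.
Compound 2 `CCC(=O)Oc1[nH]c2ccccc2c1Cc1c(OC(C)=O)ccc2ccc(=O)oc12` gives 67000 nM.

Compound 2 stands on the only number shown in this assay; the other value shown, that of compound 1, is a limit of the assay and not a number, (the limit of > 100000 nM in this assay, at which 1 of the 2 values shown sits). Among the compounds with values here, no two measured compounds differ in one place, so no step between measured compounds can be read off, and the two values give no direction for any change.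

Compound 3 `CC(=O)Oc1ccc2ccc(=O)oc2c1Cc1c(C)[nH]c2ccccc12` is not yet measured. It differs from compound 2 by methyl in place of propanoyloxy on an aromatic carbon. The measured compounds carry nothing that tracks this change. The expected step in this assay is therefore one that stays within the scatter, or at most a small move toward the less toxic end, and the step expected is a 1.2-fold higher number from compound 2 to compound 3 (0.08 log units; within the scatter). A reading at the limit of the assay, as seen for compound 1, is a real possibility. Compound 3 is estimated at 80000 nM, with a range from 30000 nM to 200000 nM.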

Compound 3, half-maximal cytotoxic concentration: 62000 nM
For compound 3 the middle estimate is 1.3-fold (0.11 log units) above the measured one, and the stated range covers the measured number.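

In this assay, within the data shown here, methyl in place of propanoyloxy on the aromatic carbon next to the ring nitrogen gives a 1.1-fold lower number from compound 2 to compound 3 (0.03 log units; within the scatter), the first step that can be read between two measured compounds. At this position, the read-out does not separate the two groups, although the leaving propanoyloxy has 5 heavy atoms and 2 hydrogen-bond acceptors, and the entering methyl has 1 heavy atom and no hydrogen-bond acceptors. Compound 1 differs from compound 3 in more than one place, so no step can be read between them, and its value is a limit of the assay and not a number: the limit of > 100000 nM in this assay, at which 1 of the 3 values shown sits.

The shown compounds leave open whether this position stays as undiscriminating with a group of another kind there, such as an amine, a carboxylic acid or a longer alkyl chain. Going by these compounds, this remains a single step on a single core in one assay, so it is also open whether the same exchange would give a step of similar size on the core of compound 1.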